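This account rests on a few compounds, and the source may have more. Where it says the series, first, only, none or still open, it means among the compounds named here.

Measured so far in an assay on isolated protein for inhibition of long-chain fatty acid transport protein 1 (Mus musculus); on this read-out higher numbers stand for weaker inhibition and lower numbers for stronger inhibition:
compound 1 `CCn1c(CNc2ccccc2)nnc1SCc1nc2cc(Cl)ccc2o1` — 2300 nM
compound 2 `CCn1c(CNc2ccccc2)nnc1SCc1nc2cc(OC(F)(F)F)ccc2o1` — 91 nM

Compound 2 has the lowest of the two numbers in this assay; its nearest neighbour is compound 1, which differs from it in one place, trifluoromethoxy in place of chloro on an aromatic carbon, and shows a 25-fold lower number from compound 1 to compound 2 (1.40 log units; beyond the scatter).

Compound 3 `CCn1c(CNc2ccccc2)nnc1SCc1nc2cc(C)ccc2o1` is not yet measured. It differs from compound 2 as follows: methyl in place of trifluoromethoxy on an aromatic carbon. For the measured compounds named here, no measured step covers methyl in place of trifluoromethoxy; the only step available, a 25-fold lower number from compound 1 to compound 2 (1.40 log units; beyond the scatter), bears on it indirectly in that it shows the same position to be sensitive to what stands there, with a large effect between the two substituents seen so far. Going by the values given here, with only one step to go on, the direction for methyl cannot be read from the measured compounds; a number somewhere between compound 1 and compound 2 is the plainest expectation, with a wide range. The estimate for compound 3 in this assay is 600 nM, between 150 nM and 3000 nM. This estimate means a step of a 6.6-fold higher number from compound 2 to compound 3 (0.82 log units; beyond the scatter).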

Compound 3, half-maximal inhibitory concentration: > 10000 nM
Compound 3 gave a limit, no number; the forecaster's own chance of this, stated with the estimate: 2%; middle value at least 16-fold (1.22 log units) away from the limit.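

Compound 3 gives a limit, not a number, in this assay: the limit of > 10000 nM in this assay, at which 1 of the 3 values shown sits.

Methyl in place of trifluoromethoxy gives an at least 100-fold higher number from compound 2 to compound 3 (2.04 log units; beyond the scatter), a larger step than the one seen earlier at this aromatic carbon, so the low number of compound 2 depends strongly on the group standing there. Methyl in place of chloro gives an at least 4.3-fold higher number from compound 1 to compound 3 (0.63 log units; beyond the scatter), which shows that methyl does not fall in the range set by the two earlier substituents and that chloro already retains more inhibition than methyl in this series of three.

The compounds shown do not separate the contribution of the oxygen in trifluoromethoxy from that of its three fluorines, a question that methoxy and trifluoromethyl at the same carbon would address directly. Also open, going by these compounds, are how a bare hydrogen, a fluoro group or an amine would read at this carbon, and whether the same sensitivity to the substituent holds when the rest of the shared core is changed.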